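The source may hold more compounds than are shown below. What is called first, only, known or untested is meant among the compounds shown, and "the series" means these compounds.

Compound 3 `Cc1cccc(-n2nncc2CN2C(=O)C3(C(C#N)=C(N)Oc4c(N)cc5nc6ccccc6nc5c43)c3ccccc32)c1` is one of three compounds tested in an ADME assay on L02 cells (Homo sapiens) for antiproliferative activity, read by MTT assay, with a stated time of 48 h; a lower number here means a stronger inhibitor, a higher number a weaker inhibitor. In this assay compound 3 gives > 50000 nM, which is a limit of the assay rather than a number. Compound 1 `Cc1cccc(-n2nncc2CN2C(=O)C3(C(C#N)=C(N)Oc4c3c3nc5ccccc5nc3c3ccccc43)c3ccccc32)c1` gives > 50000 nM in this assay, again a limit. Compound 2 `CC(=O)Nc1ccc(-n2nncc2CN2C(=O)C3(C(C#N)=C(N)Oc4c3c3nc5ccccc5nc3c3ccccc43)c3ccccc32)cc1` gives > 50000 nM in this assay, also a limit. The whole picture so far is the limit of > 50000 nM in this assay, at which 3 of the 3 values shown sit. Among the compounds with values here, the single step between measured compounds, a step that the two limits leave unreadable from compound 1 to compound 2, is therefore of unreadable size. Compound 4 `CCc1cccc(CC)c1-n1nncc1CN1C(=O)C2(C(C#N)=C(N)Oc3c(N)cc4nc5ccccc5nc4c32)c2ccccc21` differs from compound 3 in one place: 2,6-diethylphenyl in place of 3-methylphenyl on an aromatic nitrogen. Within the data shown here, no measured step touches this change, and the one available step is unreadable, so there is no ground for expecting a move beyond the scatter in either direction. The expectation is that compound 4 also gives only a limit in this assay. Compound 4 is accordingly estimated at 70000 nM, within a range from 30000 nM to 200000 nM. The step expected here, a step that the limit leaves unreadable from compound 3 to compound 4, is none beyond the scatter.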

Compound 4, half-maximal inhibitory concentration: > 50000 nM
Compound 4 was reported as a limit; the forecaster's own chance of this, stated with the estimate: 90%; the middle value does not contradict the limit.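

Within the data shown here, compound 3 and compound 4 are both reported only as limits in this assay, so the change from 3-methylphenyl to 2,6-diethylphenyl gives no step that can be read. The compounds shown leave open how any of them ranks against another, as all share one limit: the limit of > 50000 nM in this assay, at which 4 of the 4 values shown sit.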